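Oxygen-linked variations on a shared quinone core

The source may hold more compounds than are shown below. What is called first, only, known or untested is meant among the compounds shown, and "the series" means these compounds.

Compound 1 `CCOC1=CC(=O)c2ccccc2C1=O`, compound 2 `CCCCOC1=CC(=O)c2ccccc2C1=O` and compound 3 `O=C1C=C(Oc2ccco2)C(=O)c2ccccc21` share one core and differ only in the group carried on an oxygen on an unsaturated carbon. In a functional assay on HeLa cells (Homo sapiens) for cytotoxicity (a lower number here means a stronger inhibitor, a higher number a weaker inhibitor), compound 1 gives 23800 nM, compound 2 gives 35300 nM and compound 3 gives 37000 nM. The three numbers lie close together: a 1.5-fold higher number from compound 1 to compound 2 (0.17 log units; within the scatter), a 1.6-fold higher number from compound 1 to compound 3 (0.19 log units; within the scatter) and a 1.0-fold higher number from compound 2 to compound 3 (0.02 log units; within the scatter), so no one of them stands apart from the others in this assay.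

Compound 4 `C/C=C/C(=O)OC1=CC(=O)c2ccccc2C1=O` continues the series with a further exchange at the same place: (prop-1-en-1-yl)carbonyl in place of furan-2-yl on an oxygen on an unsaturated carbon. The measured steps bearing on this exchange are those at the same oxygen, from ethyl to butyl and from either chain to furan-2-yl, and all of them stayed within the scatter. On that basis the exchange to (prop-1-en-1-yl)carbonyl is expected to give no step beyond the scatter either; the estimated step is a 1.1-fold lower number from compound 3 to compound 4 (0.02 log units; within the scatter). Compound 4 is therefore estimated at 35000 nM in this assay, with a range from 15000 nM to 80000 nM.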

Compound 4, half-maximal inhibitory concentration: 37900 nM
The estimate for compound 4 lay 1.1-fold (0.03 log units) below the measured number, and the stated range covers the measured number.
By their numbers in this assay, from the lowest: compounds 1, 2, 3 and 4 (each within the scatter of the next).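

Of the four groups on this oxygen, only (prop-1-en-1-yl)carbonyl brings a carbonyl, and in this assay it stays within the scatter of all three others: a 1.0-fold higher number from compound 3 to compound 4 (0.01 log units; within the scatter), a 1.1-fold higher number from compound 2 to compound 4 (0.03 log units; within the scatter) and a 1.6-fold higher number from compound 1 to compound 4 (0.20 log units; within the scatter). The exchange from furan-2-yl also removes the five-membered aromatic ring at an equal heavy-atom count, so neither an open chain nor an aromatic ring on this oxygen separates any of the four compounds here. No measurement at hand accounts for this flat result.

On these data alone, whether a chain ending in an amine, a carboxylic acid or a longer chain such as decyl on this oxygen would give a step beyond the scatter stays open. The four compounds define this position only for ethyl, butyl, furan-2-yl and (prop-1-en-1-yl)carbonyl.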